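Propyl to isopropyl on the amine: compound 4

The source may hold more compounds than are shown below. What is called first, only, known or untested is meant among the compounds shown, and "the series" means these compounds.

Measured so far:
compound 1, `CCCN(C[C@H]1Cc2c(cccc2N2CCNCC2)CN1)[C@H]1CCCc2cccnc21`: in a functional assay on CCRF-CEM cells for agonist activity at C-X-C chemokine receptor type 4 (Homo sapiens), read by calcium flux, with a stated time of 25 min (a lower number here means that less compound is needed, a higher number that more compound is needed for the effect), compound 1 gives > 30000 nM, a limit of the assay.
compound 2, `CC(C)N1CCN(c2cccc3c2C[C@H](CN(C)[C@H]2CCCc4cccnc42)NC3)CC1`: compound 2 gives > 30000 nM, likewise a limit.
compound 3, `CN(C[C@H]1Cc2c(cccc2N2CCN3CCC[C@@H]3C2)CN1)[C@H]1CCCc2cccnc21`: compound 3 gives > 30000 nM, also a limit.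

Compound 1 therefore stands only at a limit, and all three values shown sit at the same limit (the limit of > 30000 nM in this assay, at which 3 of the 3 values shown sit). Going by the values given here, the one step between measured compounds, a step that the two limits leave unreadable from compound 2 to compound 3, is unreadable for the same reason.

Compound 4 is `CC(C)N(C[C@H]1Cc2c(cccc2N2CCNCC2)CN1)[C@H]1CCCc2cccnc21`; it differs from compound 1 by isopropyl in place of propyl on an amine nitrogen. Among the compounds with values here, no measured step touches this amine substituent, so there is nothing to read a direction or size from. Given that compound 1 gives > 30000 nM, compound 4 is expected to remain at the limit, an estimated step of a number no higher from compound 1 to compound 4 (the limit leaves the size open). The estimate for compound 4 is 30000 nM, in the range 10000 nM to 100000 nM.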

Compound 4, half-maximal effective concentration: > 30000 nM
Compound 4: a limit, no number (the forecaster's own chance of this, stated with the estimate: 85%); the middle value lies on the limit itself.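

No step can be read from compound 1 to compound 4, as both values are limits: the limit of > 30000 nM in this assay, at which 4 of the 4 values shown sit.

The compounds shown leave open how propyl and isopropyl compare on this amine nitrogen, and which structural change would give a value inside the measurable range.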